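Methyl to phenyl on the ring nitrogen of compound 3

The source may report more compounds than this note shows. Statements on the series, on what has been measured and on what is new or still open speak of the compounds shown alone.

Measured so far:
compound 1, `Cc1ccc2oc(SCC(=O)Nc3ccc(-c4nc(-c5ccccc5)c(-c5ccccc5)n4C)cc3)nc2c1`: 65.1%
compound 2, `Cn1nnnc1SCC(=O)Nc1ccc(-c2nc(-c3ccccc3)c(-c3ccccc3)n2C)cc1`: 77.7%
compound 3, `CN1CCN(CC(=O)Nc2ccc(-c3nc(-c4ccccc4)c(-c4ccccc4)n3C)cc2)CC1`: 50.3%

All three compounds share one core and differ only in the group attached to the amide carbonyl. In a functional assay on MCF7 cells (Homo sapiens) for cytotoxicity, read by MTT assay, with a stated time of 24 h, tested at 80 ug/mL (a higher number here means a stronger effect of the compound at the concentration tested, a lower number a weaker effect), compound 3 gives the lowest of the three numbers: the step of a number 14.8 percentage points lower from compound 1 to compound 3 (beyond the scatter) and the step of a number 27.4 percentage points lower from compound 2 to compound 3 (beyond the scatter) both run downward and both lie beyond the scatter, so the 4-methylpiperazin-1-yl group stands below either sulfanyl-linked ring.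

Compound 4, `Cn1c(-c2ccc(NC(=O)CN3CCN(c4ccccc4)CC3)cc2)nc(-c2ccccc2)c1-c1ccccc1`, keeps this group but changes it: phenyl in place of methyl on an amine nitrogen in a ring. Among the measured compounds shown here, none of the measured steps touches this position; the two steps that reach compound 3 exchange the whole group on the chain carbon rather than the substituent on the ring nitrogen, so they give size but no direction for this smaller change. The expectation is therefore a step of a number 4.7 percentage points higher from compound 3 to compound 4 (within the scatter) that need not leave the scatter, and compound 4 is estimated at 55%, within a range from 35% to 75%.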

Compound 4, a percentage reported as activity, at one concentration (the size of the read-out at that concentration, not a potency): 72.5%
Estimate against measurement, compound 4: 17.5 percentage points below; the measured number falls inside the stated range.
By their numbers in this assay, from the lowest: compound 3; then compounds 1, 4 and 2 (each within the scatter of the next, the first and the last beyond it).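

The earlier steps shown here exchanged the whole group on the chain carbon, whereas this one shows that the substituent on the amine nitrogen in the ring matters by itself in this assay: a number 22.2 percentage points higher from compound 3 to compound 4 (beyond the scatter). With phenyl on that nitrogen, the group no longer stands apart from the two sulfanyl-linked rings: a number 5.2 percentage points lower from compound 2 to compound 4 (within the scatter) and a number 7.4 percentage points higher from compound 1 to compound 4 (within the scatter), so 4-phenylpiperazin-1-yl cannot be told from either of them here. No measurement at hand explains the step.

On these data alone, with only phenyl and methyl on this nitrogen, it stays open whether the aromatic ring or simply the larger group goes with the higher number; a cyclohexyl or a benzyl group there would help separate the two. Also open, as far as these compounds go, is how a methoxy group or a chlorine on the new phenyl ring would change the read-out.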